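This account rests on a few compounds, and the source may have more. Where it says the series, first, only, none or still open, it means among the compounds named here.

Compound 1 `COc1ccccc1N1C(=O)CSC1c1cccc(C(=O)NCCCCc2ccc(Cl)cc2)c1` was tested in a functional assay on HOS-TE85 cells (Homo sapiens) for inhibition, read by CCK-8 assay, with a stated time of 72 h (a higher number here means a weaker inhibitor, a lower number a stronger inhibitor), where compound 1 gives 78.6 nM, the lowest of the three numbers in hand. Compound 3 `C#Cc1cccc(N2C(=O)CSC2c2cccc(C(=O)NCCCCc3ccccc3)c2)c1` gives 149 nM in this assay, a gap from compound 1 that lies within the usual scatter, while compound 2 `O=C(NCCCCc1ccccc1)c1cccc(C2OCC(=O)N2c2cccc(F)c2)c1` gives 320 nM, a gap that lies beyond it. Compound 4 `COc1ccccc1N1C(=O)CSC1c1cccc(C(=O)NCCCCn2cncn2)c1` keeps the core of compound 1 and differs from it in one place: 1H-1,2,4-triazol-1-yl in place of 4-chlorophenyl on a saturated chain carbon, four bonds along the chain from an amide-type nitrogen. Among the compounds with values here, no pair of measured compounds covers this change, so the direction rests on expectation alone. The move to compound 4 is expected to raise the number, by roughly a 4.1-fold higher number from compound 1 to compound 4 (0.61 log units; beyond the scatter). Compound 4 is therefore estimated at about 320 nM, with a likely range from 100 nM to 1500 nM.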

Compound 4, half-maximal inhibitory concentration: > 1000 nM
Compound 4 ended at the assay's limit (the forecaster's own chance of this, stated with the estimate: 5%); middle value at least 3.1-fold (0.49 log units) away from the limit.
By their numbers in this assay, from the lowest: compounds 1 and 3 (each within the scatter of the next); then compound 2. At a limit, above all of these: compound 4.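

Within the data shown here, putting 1H-1,2,4-triazol-1-yl in place of 4-chlorophenyl at the chain end gives the only measured step at this position, an at least 12-fold higher number from compound 1 to compound 4 (1.10 log units; beyond the scatter). In this assay compound 4 gives > 1000 nM, which is a limit and not a number, so the full size of the step stays unread: the limit of > 1000 nM in this assay, at which 1 of the 4 values shown sits. With the core of compound 1 held, this single change is enough to reach that limit.

On these data alone, whether a pyridine ring, a primary amine or a carboxylic acid at the chain end would keep the number low remains open. So does the effect of a shorter chain carrying the same triazole.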